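The source may report more compounds than this note shows. Statements on the series, on what has been measured and on what is new or still open speak of the compounds shown alone.

Compound 1 `O=C(NCCCCc1ccccc1)n1c(=O)oc2ccccc21` carries the unsubstituted core; in an assay on HEK293 cells for inhibition of acid ceramidase (Homo sapiens), with a stated time of 10 min (a lower number here means a stronger inhibitor, a higher number a weaker inhibitor), compound 1 gives 64 nM. Compound 2 `O=C(c1ccccc1)c1ccc2c(c1)oc(=O)n2C(=O)NCCCCc1ccccc1` gives 29 nM in this assay, and compound 3 `O=C(NCCCCc1ccccc1)n1c(=O)oc2cc(Br)ccc21` gives 31 nM in this assay. Among these three numbers compound 3 stands second highest: its value and that of compound 2 lie within the scatter of each other, while the number for compound 1 is higher, as the step of a 2.1-fold lower number from compound 1 to compound 3 (0.31 log units; beyond the scatter) shows. Compound 4 `O=C(c1ccc(Cl)cc1)c1ccc2c(c1)oc(=O)n2C(=O)NCCCCc1ccccc1` differs from compound 3 by (4-chlorophenyl)carbonyl in place of bromo on an aromatic carbon. Within the data shown here, two measured steps bear on this change. The step of a 1.1-fold higher number from compound 2 to compound 3 (0.03 log units; within the scatter) shows that a bromo in place of a benzoyl at this position changed nothing beyond the scatter, and the step of a 2.2-fold lower number from compound 1 to compound 2 (0.34 log units; beyond the scatter) was of about the same size as the step of a 2.1-fold lower number from compound 1 to compound 3 (0.31 log units; beyond the scatter). On that basis compound 4 is expected to show no step beyond the scatter in this assay, namely a 1.2-fold lower number from compound 3 to compound 4 (0.08 log units; within the scatter). The estimate for compound 4 in this assay is 26 nM, with a range from 10 nM to 70 nM.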

Compound 4, half-maximal inhibitory concentration in the acid ceramidase assay: 14 nM
Estimate against measurement, compound 4: 1.9-fold (0.27 log units) above; the range from low to high includes it.
By their numbers in the acid ceramidase assay, from the lowest: compound 4; then compounds 2 and 3 (each within the scatter of the next); then compound 1.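

In the acid ceramidase assay, bromo and benzoyl had stood within the scatter of each other at this position, but chloro on the benzoyl ring adds a step of its own, a 2.1-fold lower number from compound 2 to compound 4 (0.32 log units; beyond the scatter), so the outer ring of the group also counts. The exchange of bromo for the whole (4-chlorophenyl)carbonyl group gives a 2.2-fold lower number from compound 3 to compound 4 (0.35 log units; beyond the scatter), and the same group in place of hydrogen gives a 4.6-fold lower number from compound 1 to compound 4 (0.66 log units; beyond the scatter), the largest step shown in this assay. The exchange of bromo also separates the two compounds in a physicochemical assay for metabolic stability, read by HPLC, in phosphate buffer, at pH 7.4, tested at 10 uM (a lower number here means that the compound disappears faster, a higher number that the compound lasts longer), where compound 3 gives 0.4 h and compound 4 gives 4.57 h, so that compound 4 lasts longer than compound 3: the measured half-life of compound 3, 0.4 h, and of compound 4, 4.57 h, an 11-fold higher number (1.06 log units; beyond the scatter)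

From the compounds shown here alone, whether fluoro or methoxy in place of the chloro would give a step of the same size stays open, as does whether an amine on that ring would keep the longer half-life in the physicochemical assay.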